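Moving the chlorine on the phenyl attached to the aromatic nitrogen

The compounds below may be only part of what the source reports. "The series", "measured", "known", "first", "only" and "open" are said of these compounds alone.

Compound 1, `Cc1ccc(-n2cc(-c3cccc(NS(=O)(=O)c4c[nH]c(=O)[nH]c4=O)c3)nn2)cc1`: in a functional assay on A549 cells (Homo sapiens) for antiproliferative activity, read by MTT assay, with a stated time of 24 h (on this read-out higher numbers stand for weaker inhibition and lower numbers for stronger inhibition), compound 1 gives 3630 nM.
Compound 2, `O=c1[nH]cc(S(=O)(=O)Nc2cccc(-c3cn(-c4ccccc4F)nn3)c2)c(=O)[nH]1`: compound 2 reaches only the assay limit of > 20000 nM.
Compound 3, `O=c1[nH]cc(S(=O)(=O)Nc2cccc(-c3cn(-c4cccc(Cl)c4)nn3)c2)c(=O)[nH]1`: compound 3 gives 2430 nM.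

Of the two numbers shown, compound 3 has the lower one, but compound 1 sits within the scatter of it; the third value is a limit. Compound 4, `O=c1[nH]cc(S(=O)(=O)Nc2cccc(-c3cn(-c4ccc(Cl)cc4)nn3)c2)c(=O)[nH]1`, differs from compound 3 by 4-chlorophenyl in place of 3-chlorophenyl on an aromatic nitrogen. For the measured compounds named here, two measured steps bear on this change. The step of a 1.5-fold lower number from compound 1 to compound 3 (0.17 log units; within the scatter) shows that 4-methylphenyl and 3-chlorophenyl give much the same number, whereas an at least 5.5-fold higher number from compound 1 to compound 2 (0.74 log units; beyond the scatter) and an at least 8.2-fold lower number from compound 2 to compound 3 (0.91 log units; beyond the scatter) set 2-fluorophenyl far apart. With a 4-substituted phenyl in compound 1 and a 3-substituted phenyl in compound 3 so close, compound 4 is expected to show no step beyond the scatter: a 1.2-fold higher number from compound 3 to compound 4 (0.06 log units; within the scatter). Compound 4 is therefore estimated at 2800 nM, in a range from 1200 nM to 7000 nM.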

Compound 4, half-maximal inhibitory concentration: 1730 nM
Beside the measured number, compound 4's estimate is 1.6-fold (0.21 log units) above it, and the stated range covers the measured number.
By their numbers in this assay, from the lowest: compounds 4, 3 and 1 (each within the scatter of the next, the first and the last beyond it). At a limit, above all of these: compound 2.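

Moving the chlorine from the 3-chlorophenyl to the 4-chlorophenyl leaves the number within the scatter (a 1.4-fold lower number from compound 3 to compound 4 (0.15 log units; within the scatter)). Chloro in place of methyl, by contrast, gives a modest step beyond the scatter (a 2.1-fold lower number from compound 1 to compound 4 (0.32 log units; beyond the scatter)), so the choice of group on this phenyl can register even where moving the chlorine does not. One step is large (an at least 11-fold lower number from compound 2 to compound 4 (1.06 log units; beyond the scatter)), but it is read against a limit: the limit of > 20000 nM in this assay, at which 1 of the 4 values shown sits.

The compounds shown leave open whether a methoxy, an amine or a carboxylic acid in place of the chlorine of compound 4 would keep its number. Nor do they tell whether compound 2 stands apart for its fluorine or for where that fluorine sits.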